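From a 4-Fluorobenzyl Ether to an Ethyl Ether

The compounds below may be only part of what the source reports. "The series", "measured", "known", "first", "only" and "open" are said of these compounds alone.

Measured so far:
compound 1 `CN(C)CCCNc1ccnc2cc(OCc3ccc(F)cc3)ccc12` gives 940 nM
compound 2 `Fc1ccc(COc2ccc3c(Cl)ccnc3c2)cc1` gives 2230 nM

Both compounds were tested in a functional assay on NCI-H1650 cells (Homo sapiens) for cytotoxicity, read by MTT assay, with a stated time of 48 h; a lower number here means a stronger inhibitor, a higher number a weaker inhibitor. For the measured compounds named here, compound 1 stands at the lower of the two numbers, so it is the stronger inhibitor of the pair; the one measured step, a 2.4-fold higher number from compound 1 to compound 2 (0.38 log units; beyond the scatter), comes from a change at the amine side of the shared core, where chloro replaces the (3-(dimethylamino)propyl)amino group.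

Compound 3 `CCOc1ccc2c(NCCCN(C)C)ccnc2c1` keeps that amine side chain untouched and instead changes the other end of the molecule: methyl in place of 4-fluorophenyl on a saturated chain carbon bound to an oxygen on an aromatic ring. In other words, the 4-fluorobenzyl group on the ether oxygen becomes a simple ethyl group.

Going by the values given here, no measured step covers this kind of change; the only step recorded concerns a different position. The expectation for compound 3 therefore rests on little, and the removal of a ring from the ether end is a sizeable change to the molecule. A somewhat weaker inhibitor is expected, with a step of a 2.1-fold higher number from compound 1 to compound 3 (0.33 log units; beyond the scatter). Compound 3 is estimated at 2000 nM, within a range of 600 nM to 7000 nM.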

Compound 3, half-maximal inhibitory concentration: 3830 nM
Compound 3: the middle estimate sits 1.9-fold (0.28 log units) below what was measured, and the stated range covers the measured number.
By their numbers in this assay, from the lowest: compound 1; then compounds 2 and 3 (each within the scatter of the next).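

The ether end of the molecule turns out to matter as well as the amine side: in this assay, replacing 4-fluorobenzyl with ethyl gives a 4.1-fold higher number from compound 1 to compound 3 (0.61 log units; beyond the scatter) and the side chain stays untouched. The change removes 4-fluorophenyl, with its six-membered aromatic ring, and leaves a single methyl carbon in its place, so a number that moves beyond the scatter shows that this position does not tolerate the swap without loss, though the loss is modest, and compound 1 remains the strongest inhibitor of the three. Nothing available explains why the number rises, so the result stands as an observation without a cause.

With only these two ether groups compared, the loss cannot yet be assigned to the fluorine, the aromatic ring or the overall size of the group. A plain benzyl group would separate the fluorine from the ring, while a longer chain such as butyl would show whether a larger group without a ring can bring the number back down.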